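Working notes: a benzyl ether swap across two cores

A few compounds are considered here, and "the series" means these few. Any claim that something is new, unique, unknown or untested is made for them only; others in the source may bear on it.

Measured so far:
Compound 1 `Cc1ccc(NC(=S)NC(=O)c2ccc(OCc3cccc(C(F)(F)F)c3)cc2)cc1-c1nc2ccccc2[nH]1`: 8200 nM
Compound 2 `Cc1ccc(NC(=S)NC(=O)c2ccc(OCc3ccccc3F)cc2)cc1-c1nc2ccccc2[nH]1`: 1870 nM
Compound 3 `Cc1ccc(NC(=O)NC(=O)c2ccc(OCc3cccc(C(F)(F)F)c3)cc2)cc1-c1nc2ccccc2[nH]1`: 3520 nM

In a functional assay on HT-29 cells (Homo sapiens) for inhibition, read by MTT assay, with a stated time of 48 h (a lower number here means a stronger inhibitor, a higher number a weaker inhibitor), compound 1 gives 8200 nM. Compound 2 differs from it by 2-fluorophenyl in place of 3-(trifluoromethyl)phenyl on a saturated chain carbon bound to an oxygen on an aromatic ring and made a 4.4-fold lower number from compound 1 to compound 2 (0.64 log units; beyond the scatter). The cores of compound 1 and compound 3 differ in a way that is not broken down here; their two values show compound 3 at the lower number, a gap given as beyond the scatter, while compound 3 and compound 2 sit within the scatter of each other.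

Compound 4 `Cc1ccc(NC(=O)NC(=O)c2ccc(OCc3ccccc3F)cc2)cc1-c1nc2ccccc2[nH]1` is not yet measured. It differs from compound 3 by 2-fluorophenyl in place of 3-(trifluoromethyl)phenyl on a saturated chain carbon bound to an oxygen on an aromatic ring, the same change made from compound 1 to compound 2, at the same place. A single earlier example is thin ground, so the expectation is tempered toward a smaller step than the one seen. Compound 4 is expected to move by a 3.2-fold lower number from compound 3 to compound 4 (0.51 log units; beyond the scatter), resting on the earlier step of a 4.4-fold lower number from compound 1 to compound 2 (0.64 log units; beyond the scatter). Compound 4 is estimated at 1100 nM in this assay, with a likely range from 400 nM to 3000 nM.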

Compound 4, half-maximal inhibitory concentration: 760 nM
For compound 4 the middle estimate is 1.4-fold (0.16 log units) above the measured one; the measured number falls inside the stated range.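

In this assay, 2-fluorophenyl in place of 3-(trifluoromethyl)phenyl gives a 4.6-fold lower number from compound 3 to compound 4 (0.67 log units; beyond the scatter). Set beside the same change on the core of compound 1, the step carries over with its size intact: the same change on two cores in this assay, a 4.4-fold lower number (0.64 log units; beyond the scatter) from compound 1 to compound 2 and a 4.6-fold lower number (0.67 log units; beyond the scatter) from compound 3 to compound 4, 1.1-fold (0.02 log units) apart, within the scatter of two such steps

Going by these compounds alone, this supports treating the change as transferable between these two cores in this assay, but it rests on only two pairs and does not show that the step would hold on any other core or explain its origin.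

On these data alone, how a plain phenyl, or a phenyl carrying an amine or a carboxylic acid, would behave at the same place on either core remains open. Also open, as far as these compounds go, is whether the step would appear in any other assay.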